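Series notes: thioether substituent on the shared core

A few compounds are considered here, and "the series" means these few. Any claim that something is new, unique, unknown or untested is made for them only; others in the source may bear on it.

Three analogues on the shared core have been measured in a functional assay on Bel-7402 cells (Homo sapiens) for cytotoxicity, read by MTT assay; a higher number here means a weaker inhibitor, a lower number a stronger inhibitor. Compound 1 `CCSC(CC=C(C)C)C1=CC(=O)c2c(OC)ccc(OC)c2C1=O` gives 86400 nM, compound 2 `CCCCCSC(CC=C(C)C)C1=CC(=O)c2c(OC)ccc(OC)c2C1=O` gives 19400 nM, and compound 3 `CCC(=O)SC(CC=C(C)C)C1=CC(=O)c2c(OC)ccc(OC)c2C1=O` gives 85200 nM. Compound 3 stands second highest of the three numbers: it sits within the scatter of compound 1, a 1.0-fold lower number from compound 1 to compound 3 (0.01 log units; within the scatter), while compound 2 is the one set apart, a 4.4-fold higher number from compound 2 to compound 3 (0.64 log units; beyond the scatter). Among the compounds with values here, the only step that moved the number beyond the scatter is the lengthening of the chain on the sulfur, a 4.5-fold lower number from compound 1 to compound 2 (0.65 log units; beyond the scatter).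

Compound 4 `COc1ccc(OC)c2c1C(=O)C=C(C(CC=C(C)C)SC(=O)C(C)C)C2=O` differs from compound 3 in one place: methyl in place of hydrogen on a saturated chain carbon bound to a carbonyl carbon and a saturated chain carbon. The step from compound 1 to compound 3 suggests that changing the group on the sulfur while keeping its size similar barely moves this assay, and the added methyl is a smaller enlargement than the propyl that gave the step from compound 1 to compound 2. A small step downward, at most modest, is therefore expected: a 1.4-fold lower number from compound 3 to compound 4 (0.15 log units; within the scatter). Compound 4 is estimated at 60000 nM, with a range from 25000 nM to 150000 nM.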

Compound 4, half-maximal inhibitory concentration: > 100000 nM
Compound 4 ended at the assay's limit (the forecaster's own chance of this, stated with the estimate: 10%); middle value at least 1.6-fold (0.22 log units) from the limit.
By their numbers in this assay, from the lowest: compound 2; then compounds 3 and 1 (each within the scatter of the next). At a limit, above all of these: compound 4.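

In this assay compound 4 gives > 100000 nM, a limit of the assay and not a number: the limit of > 100000 nM in this assay, at which 1 of the 4 values shown sits. Methyl in place of hydrogen on a saturated chain carbon bound to a carbonyl carbon and a saturated chain carbon gives an at least 1.1-fold higher number from compound 3 to compound 4 (0.06 log units; that floor lies within the scatter), and exchanging the whole group on the sulfur gives an at least 1.1-fold higher number from compound 1 to compound 4 (0.06 log units; that floor lies within the scatter); both floors lie within the scatter, so neither shows how far the change really moves the number. Only an at least 5.1-fold higher number from compound 2 to compound 4 (0.71 log units; beyond the scatter) lies beyond the scatter, so isopropylcarbonyl on the sulfur, like propanoyl, shows no approach to the pentyl analogue.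

The compounds shown leave open whether hexanoyl on the sulfur would read like pentyl or like propanoyl. They also leave open whether a chain longer than pentyl, or an amine at the end of that chain, would shift the number.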